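The source may report more compounds than this note shows. Statements on the series, on what has been measured and on what is new or still open speak of the compounds shown alone.

Compound 1 `Fc1cccc(F)c1CSc1nnc(-c2ccncc2)n1-c1ccccc1`: in a functional assay on HepG2 cells (Homo sapiens) for inhibition, read by MTT assay, with a stated time of 48 h (on this read-out lower numbers stand for stronger inhibition and higher numbers for weaker inhibition), compound 1 gives > 50000 nM, which is a limit of the assay and not a number.
Compound 2 `O=[N+]([O-])c1cccc(CSc2nnc(-c3ccncc3)n2-c2ccccc2)c1`: in this assay compound 2 gives 22000 nM.
Compound 3 `O=C(CSc1nnc(-c2ccncc2)n1-c1ccccc1)N/N=C/c1ccccc1`: in this assay compound 3 gives 18600 nM.

Compound 3 stands at the lowest of the two numbers shown. Its nearest neighbour is compound 2, whose value lies within the scatter of that of compound 3, so no order between the two can be drawn. Compound 1 contributes only a limit.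

Compound 4 `COc1ccc(/C=N/NC(=O)CSc2nnc(-c3ccncc3)n2-c2ccccc2)cc1` differs from compound 3 in methoxy in place of hydrogen on an aromatic carbon. For the measured compounds named here, the only measured step, an at least 2.2-fold lower number from compound 1 to compound 2 (0.35 log units; beyond the scatter), concerns a different part of the shared core, the group on the saturated chain carbon bound to a sulfur, and it rests on a limit (the limit of > 50000 nM in this assay, at which 1 of the 3 values shown sits), so it gives no direct guidance for a methoxy entering the phenyl that becomes 4-methoxyphenyl. Going by the values given here, no measured step bears on this change. The step of a 1.2-fold lower number from compound 3 to compound 4 (0.09 log units; within the scatter) is therefore expected to stay within the scatter, with no direction favoured. On that basis compound 4 is estimated to give about 15000 nM in this assay, within a range from 6000 nM to 40000 nM.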

Compound 4, half-maximal inhibitory concentration: 27100 nM
Compound 4: middle estimate off by 1.8-fold (0.26 log units), on the low side, within the range that was stated.
By their numbers in this assay, from the lowest: compounds 3, 2 and 4 (each within the scatter of the next). At a limit, above all of these: compound 1.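

Methoxy in place of hydrogen, para to a large group on an aromatic carbon, is the only measured step at this position, and in this assay it amounts to a 1.5-fold higher number from compound 3 to compound 4 (0.16 log units; within the scatter) on this read-out. The earlier compounds shown here said nothing about this ring, and the new step shows that a phenyl and a 4-methoxyphenyl here cannot be told apart by this read-out, so the change has no direction that can be stated. Nothing available bears on this step or offers a reason for its size.

What the compounds shown leave open is whether any other group in place of that hydrogen, such as a hydroxyl, a dimethylamino group, a carboxylic acid or a longer alkoxy chain, would give a number outside the scatter of the phenyl compound. Since compounds 2, 3 and 4 each lie within the scatter of the next in the order of their numbers, they also leave open which change, at this position or elsewhere on the shared core, would carry a number clearly below that group of values.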